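From Methyl to Isobutyl on a Chain Carbon

The source may report more compounds than this note shows. Statements on the series, on what has been measured and on what is new or still open speak of the compounds shown alone.

Of the compounds shown here, two built on a shared core have been measured so far. In a functional assay on MCF7 cells (Homo sapiens) for antiproliferative activity (on this read-out higher numbers stand for weaker inhibition and lower numbers for stronger inhibition), compound 2 (`C[C@H](NC(=O)OC(C)(C)C)C(=O)Nc1ccc(O)c2c(=O)cc(-c3ccccc3Cl)oc12`) gives 5500 nM, the higher of the two numbers and so the weaker inhibition, while compound 1 (`CC(C)C[C@@H](NC(=O)OC(C)(C)C)C(=O)Nc1ccc(O)c2c(=O)cc(-c3ccccc3Cl)oc12`) gives 2500 nM. That gap lies just beyond the usual scatter of repeated measurements.

The next compound, compound 3 (`CC(C)C[C@H](NC(=O)OC(C)(C)C)C(=O)Nc1ccc(O)c2c(=O)cc(-c3ccccc3Cl)oc12`), is compound 2 with a single change: isopropyl in place of hydrogen on a saturated chain carbon, two bonds along the chain from an amide-type nitrogen and a carbonyl carbon. In words, isopropyl stands in place of hydrogen on a saturated chain carbon, two bonds along the chain from an amide-type nitrogen and a carbonyl carbon, which turns methyl into isobutyl.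

Going by the values given here, no measured pair shows this change on its own. The nearest guide is compound 1 at 2500 nM, which also carries isobutyl, though with the opposite handedness at that chain carbon, so it is only a loose guide. A modest move towards stronger inhibition in this assay is expected, with an estimated size of a 1.8-fold lower number from compound 2 to compound 3 (0.26 log units; within the scatter). Compound 3 is expected at 3000 nM, with an estimated range from 1100 nM to 8000 nM.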

Compound 3, half-maximal inhibitory concentration: 4000 nM
Estimate against measurement, compound 3: 1.3-fold (0.12 log units) below, and the stated range covers the measured number.
By their numbers in this assay, from the lowest: compounds 1, 3 and 2 (each within the scatter of the next, the first and the last beyond it).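

In this assay, exchanging methyl for isobutyl on the saturated chain carbon, with nothing else altered, comes to a 1.4-fold lower number from compound 2 to compound 3 (0.14 log units; within the scatter), so at this position the two groups cannot be told apart on this read-out. Reversing the handedness at the same carbon gives a 1.6-fold higher number from compound 1 to compound 3 (0.20 log units; within the scatter), which also stays within the scatter, so on these numbers the configuration drawn there does not separate the two isobutyl compounds. This comparison of handedness is a clean one, since nothing else varies within the pair: the fact that compounds 1 and 3 differ only in the configuration as drawn

On these data alone, whether this position would respond to a different kind of group, such as an amine, a carboxylic acid or a longer chain on that carbon, remains open, as does the effect of reversing the handedness of the methyl compound. Going by these compounds alone, with only three compounds in a single cell assay, these results also cannot say how the same changes would read elsewhere on the shared core.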